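A Fluoro Substituent on the Anilino Ring

The compounds below may be only part of what the source reports. "The series", "measured", "known", "first", "only" and "open" are said of these compounds alone.

Compound 1 `N#Cc1c(Nc2ccccc2)sc2ccccc12` is the weaker of the two measured compounds in a functional assay on HUVEC cells (Homo sapiens), read by fluorescence and microscopy, with a stated time of 6 h, tested at 10 uM; on this read-out higher numbers stand for a weaker effect at the one concentration tested and lower numbers for a stronger effect: compound 1 gives 81%, the highest of the two numbers, and its nearest neighbour in the series is compound 2 `N#Cc1c(Nc2ccccc2O)sc2ccccc12`, which in this assay gives 19%. For the measured compounds named here, the single measured step, a number 62 percentage points lower from compound 1 to compound 2 (beyond the scatter), is a large one and lies beyond the scatter. Compound 3 `N#Cc1c(Nc2ccc(F)cc2)sc2ccccc12` has not yet been measured in this assay. It differs from compound 1 by fluoro in place of hydrogen on an aromatic carbon, the new group sitting on an aromatic carbon of a six-membered aromatic ring of carbon only, para to a large group. Going by the values given here, no measured step involves a fluoro group, and the step from compound 1 to compound 2 concerns a hydroxy group, which brings a donor and an acceptor where fluoro brings none, so it offers only weak guidance. The estimate for compound 3 is therefore a step of a number 9 percentage points lower from compound 1 to compound 3 (within the scatter), expected to be small and within the scatter, giving an estimated value of 72% with a range from 40% to 100% in this assay.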

Compound 3, a percentage reported as activity, at one concentration (the size of the read-out at that concentration, not a potency): 25%
For compound 3 the middle estimate is 47 percentage points above the measured one; the measured number lies below the stated range.
By their numbers in this assay, from the lowest: compounds 2 and 3 (each within the scatter of the next); then compound 1.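

In this assay, a single fluoro on an aromatic carbon, para to a large group, gives a number 56 percentage points lower from compound 1 to compound 3 (beyond the scatter), so this position on the six-membered aromatic ring of carbon only responds strongly to a change of just one heavy atom. The earlier step, a number 62 percentage points lower from compound 1 to compound 2 (beyond the scatter), came with a hydroxy group and left open whether a large step needed an entering group with a hydrogen-bond donor or acceptor, but fluoro counts neither and still gives a large step towards a stronger effect on this read-out. Nothing available explains why a fluoro substituent has such a large effect here, and the data give no measured property of the compounds that would account for the step.

The compounds shown leave open whether the step belongs to fluoro itself or would also follow from another group at the same place, such as chloro, methoxy or an amine. They also leave open how fluoro would behave on another carbon of this ring, and whether two such groups on the one ring would add to each other.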